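The compounds below may be only part of what the source reports. "The series", "measured", "known", "first", "only" and "open" are said of these compounds alone.

Measured compounds:
Compound 1 `O=C1c2ccccc2S(=O)(=O)N1CCCCCN1CCN(c2ncccn2)CC1` in an assay on HEK293 cells for displacement of a labelled ligand from 5-hydroxytryptamine receptor 6 (Homo sapiens) (a higher number here means a weaker inhibitor, a lower number a stronger inhibitor), gives 7100 nM.
Compound 2 `O=C1c2ccccc2S(=O)(=O)N1CCCCCN1CCN(c2cccc3ccccc23)CC1` in this assay gives 101 nM.
Compound 3 `O=C1c2ccccc2S(=O)(=O)N1CCCCCN1CCN(c2ccccn2)CC1` in this assay gives 2630 nM.

Compound 3 stands second highest of the three numbers, nearest to compound 1 and far from compound 2. The steps that lead to it are a 2.7-fold lower number from compound 1 to compound 3 (0.43 log units; beyond the scatter) and a 26-fold higher number from compound 2 to compound 3 (1.42 log units; beyond the scatter), while the move a 70-fold lower number from compound 1 to compound 2 (1.85 log units; beyond the scatter) links the two ends of the series.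

Compound 4 `O=C1c2ccccc2S(=O)(=O)N1CCCCCN1CCN(c2ccccc2)CC1` is not yet measured. It differs from compound 3 in one place: phenyl in place of pyridin-2-yl on an amine nitrogen in a ring. Within the data shown here, two measured steps bear on this. The step from compound 1 to compound 3 removed one ring nitrogen from the group on the amine nitrogen and gave a modest lowering; the step from compound 3 to compound 2 put an all-carbon ring system in that place and gave a large lowering. Compound 4 removes the remaining ring nitrogen but keeps a single six-membered ring, so a modest lowering in this assay, roughly of the size seen in the first of these steps, is expected rather than the large one seen with naphthalen-1-yl. The step from compound 3 to compound 4 is therefore estimated as a 2.6-fold lower number from compound 3 to compound 4 (0.42 log units; beyond the scatter). For compound 4 the expected value is 1000 nM, with a range from 300 nM to 3000 nM.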

Compound 4, inhibition constant: 1840 nM
Compound 4: the middle estimate sits 1.8-fold (0.26 log units) below what was measured; low and high end bracket the measured number.
By their numbers in this assay, from the lowest: compound 2; then compounds 4 and 3 (each within the scatter of the next); then compound 1.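

On the amine nitrogen in the ring, putting phenyl in place of pyridin-2-yl removes the ring nitrogen and its hydrogen-bond acceptor, and in this assay this gives a 1.4-fold lower number from compound 3 to compound 4 (0.16 log units; within the scatter) with no readable effect on the number, so this one ring nitrogen can be exchanged for carbon here without a difference that stands out from the scatter. Phenyl also gives a 3.9-fold lower number from compound 1 to compound 4 (0.59 log units; beyond the scatter) and thus a modest step from the pyrimidin-2-yl group, while an 18-fold higher number from compound 2 to compound 4 (1.26 log units; beyond the scatter) shows a large gap that remains between two groups of carbon only, so the absence of ring nitrogen does not on its own reach the low number of compound 2. Nothing in the data given here explains the size of these steps.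

On these data alone, it remains open whether the low number of compound 2 depends on the second ring itself or on the way it is attached, which naphthalen-2-yl or a quinolinyl group at the same place could address. As far as these compounds go, it is equally open how a phenyl ring carrying a methoxy group or a chlorine atom would compare with compound 4, or how a shorter or longer chain to the core would alter these steps.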